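Swapping tert-Butyl for Cyclohexyl on an Amide Nitrogen

This account rests on a few compounds, and the source may have more. Where it says the series, first, only, none or still open, it means among the compounds named here.

Of the compounds shown here, three have been measured in a functional assay on A2780cisR cells (Homo sapiens) for cytotoxicity, read by MTT assay, with a stated time of 72 h; a lower number here means a stronger inhibitor, a higher number a weaker inhibitor. Compound 1 `CCCCNC(=O)CN(CCCCCC(=O)NO)C(=O)c1ccc(N(C)C)cc1` gives 3190 nM. Compound 2 `O=C(CCCCCN(C(=O)c1ccccc1)C1(C(=O)NC2CCCCC2)CCCCC1)NO` gives 50500 nM. Compound 3 `CC(C)(C)NC(=O)CN(CCCCCC(=O)NO)C(=O)c1ccccc1` gives 42400 nM. Among these three numbers compound 3 stands second highest: its value and that of compound 2 lie within the usual scatter of each other, so no order between them can be claimed, while compound 1 sits clearly lower, beyond the scatter.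

Compound 4 `O=C(CCCCCN(CC(=O)NC1CCCCC1)C(=O)c1ccccc1)NO` has not yet been measured in this assay. It differs from compound 3 in one place: cyclohexyl in place of tert-butyl on an amide-type nitrogen. Among the compounds with values here, no measured pair shows this exact change on an otherwise identical core, so the size of the step has to be judged from the structures alone. A cyclohexyl group on this amide-type nitrogen also appears in compound 2, but that compound differs from compound 4 in further places, so its value is only a loose guide.

For compound 4 a value near 28000 nM is expected, within a range of 9000 nM to 80000 nM. The expected step of a 1.5-fold lower number from compound 3 to compound 4 (0.18 log units; within the scatter) would be modest, and may well fall within the scatter.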

Compound 4, half-maximal inhibitory concentration: 8210 nM
Beside the measured number, compound 4's estimate is 3.4-fold (0.53 log units) above it; the whole stated range lies above it.
By their numbers in this assay, from the lowest: compound 1; then compound 4; then compounds 3 and 2 (each within the scatter of the next).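

Cyclohexyl in place of tert-butyl on an amide-type nitrogen gives a 5.2-fold lower number from compound 3 to compound 4 (0.71 log units; beyond the scatter) in this assay, so the group on this nitrogen can move the number by more than the usual scatter. Within the data shown here, the earlier compounds could not show this: no two of them differ in one place only, and this single pair is the first step that can be read. The change adds carbon atoms and a six-membered non-aromatic ring of carbon only, but no measurement shown here explains why the number falls.

Counts alone cannot separate the ring from the added carbon atoms, so a straight hexyl chain, which has six carbons and no ring, or a cyclopentyl ring on the same nitrogen would be needed to tell the two apart. On these data alone, it also stays open whether the same swap gives a similar step on another core, since compound 2 carries a cyclohexyl group on this kind of nitrogen but differs from compound 4 in further places and so gives no clean comparison.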